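Swapping Chloro for Bromo: a Step Expected Within Scatter

The source may hold more compounds than are shown below. What is called first, only, known or untested is meant among the compounds shown, and "the series" means these compounds.

Compound 1 `COc1ccc(-c2cc(=O)c3c(OC)cc(OC)cc3n2C)cc1` gives 28000 nM in a functional assay on SUP-B15 cells (Homo sapiens) for antiproliferative activity, with a stated time of 72 h; on this read-out higher numbers stand for an effect only at larger amounts of compound and lower numbers for an effect already at smaller amounts.
Compound 2 `C=CCNC(=O)n1c(-c2ccc(OC)cc2)cc(=O)c2c(OC)cc(OC)cc21` gives 16000 nM in this assay.
Compound 3 `COc1ccc(-c2c(Cl)c(=O)c3c(OC)cc(OC)cc3n2S(=O)(=O)c2ccc(OC)cc2)cc1` gives 17900 nM in this assay.

Of the compounds shown here, three sharing one core have been measured so far. Compound 3 holds the second highest number of the three, but its value sits within the usual scatter of both neighbours: compound 2 is its nearest, compound 1 its furthest, and neither gap can be called a real difference.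

The new compound 4 `COc1ccc(-c2c(Br)c(=O)c3c(OC)cc(OC)cc3n2S(=O)(=O)c2ccc(OC)cc2)cc1` differs from compound 3 in a single place: bromo in place of chloro on an aromatic carbon. Among the compounds with values here, no measured pair shows this kind of exchange. Within the data shown here, the only step between compounds that differ in one place, a 1.8-fold lower number from compound 1 to compound 2 (0.24 log units; within the scatter), concerns a different position and a different kind of group, and it too stayed within the scatter, so it offers no guidance on a halogen swap. Among the measured compounds shown here, with no step pointing either way, no change beyond the scatter is expected for compound 4 in this assay.

Compound 4 is therefore estimated at 17000 nM, with a range from 8000 nM to 36000 nM. This estimate means an expected step of a 1.1-fold lower number from compound 3 to compound 4 (0.02 log units; within the scatter).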

Compound 4, half-maximal effective concentration: 2920 nM
The estimate for compound 4 lay 5.8-fold (0.77 log units) above the measured number, outside the stated range (below it).
By their numbers in this assay, from the lowest: compound 4; then compounds 2, 3 and 1 (each within the scatter of the next).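

In this assay this aromatic carbon, ortho to a 4-methoxyphenyl group, turns out to matter: bromo in place of chloro gives a 6.1-fold lower number from compound 3 to compound 4 (0.79 log units; beyond the scatter) and so an effect already at smaller amounts of compound. Within the data shown here, the change is small on paper, one heavy atom for one heavy atom, with no ring, hydrogen-bond donor, hydrogen-bond acceptor or net charge gained or lost, whereas the only earlier one-place step, a 1.8-fold lower number from compound 1 to compound 2 (0.24 log units; within the scatter) and on the aromatic nitrogen, gave no real difference. No measurement at hand explains why this halogen exchange has an effect of this size.

Going by these compounds, whether iodo, fluoro, a nitrile or an amine on the same carbon would bring the number further down or back up remains open, so this single pair sets no trend across groups at this position. On these data alone, it is also open whether bromo would give a similar step on compounds carrying the methyl of compound 1 or the allylcarbamoyl group of compound 2 on the ring nitrogen, in place of the (4-methoxyphenyl)sulfonyl group.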